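The source may hold more compounds than are shown below. What is called first, only, known or untested is meant among the compounds shown, and "the series" means these compounds.

Measured in a functional assay on HT-29 cells (Homo sapiens) for inhibition, read by luminescence and CellTiter-Glo, with a stated time of 24 h; a higher number here means that more compound is needed for the effect, a lower number that less compound is needed:
- Compound 1 `CC(C)Cn1nc(C(=O)N[C@H]2COc3ccccc3N(C)C2=S)nc1Cc1ccccc1`: 1230 nM
- Compound 2 `CN1C(=S)[C@@H](NC(=O)c2nc(Cc3ccccc3)n(CCC(F)(F)F)n2)COc2ccccc21`: 1550 nM
- Compound 3 `CN1C(=S)[C@@H](NC(=O)c2nc(Cc3ccccc3)n(C3CCNCC3)n2)COc2ccccc21`: 1000 nM

Compound 3, at 1000 nM, stands within the scatter of both other compounds, so the three values cannot be ranked. The next compound, compound 4 `Cc1cnc(-n2nc(C(=O)N[C@H]3COc4ccccc4N(C)C3=S)nc2Cc2ccccc2)nc1`, has 5-methylpyrimidin-2-yl in place of piperidin-4-yl on an aromatic nitrogen.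

Among the measured compounds shown here, three measured steps bear on this change because they alter the same side of the core: a 1.3-fold higher number from compound 1 to compound 2 (0.10 log units; within the scatter), a 1.2-fold lower number from compound 1 to compound 3 (0.09 log units; within the scatter) and a 1.6-fold lower number from compound 2 to compound 3 (0.19 log units; within the scatter). All three are small and within the scatter. For the measured compounds named here, none of the measured compounds, however, has an aromatic ring on this nitrogen, so the new group lies outside what has been tested. The expectation in this assay is therefore no step beyond the scatter, in either direction, though with a wide margin. The estimated step is a 1.2-fold higher number from compound 3 to compound 4 (0.08 log units; within the scatter). Compound 4 is expected at 1200 nM, with an estimated range from 450 nM to 3200 nM.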

Compound 4, half-maximal effective concentration: 1950 nM
Beside the measured number, compound 4's estimate is 1.6-fold (0.21 log units) below it, and the stated range covers the measured number.
By their numbers in this assay, from the lowest: compounds 3, 1, 2 and 4 (each within the scatter of the next).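

In this assay compound 4 carries the first aromatic ring on this nitrogen, and all three steps to it stay within the scatter (a 2.0-fold higher number from compound 3 to compound 4 (0.29 log units; within the scatter)), (a 1.3-fold higher number from compound 2 to compound 4 (0.10 log units; within the scatter)) and (a 1.6-fold higher number from compound 1 to compound 4 (0.20 log units; within the scatter)). The position therefore takes 5-methylpyrimidin-2-yl, as it takes the non-aromatic groups piperidin-4-yl, isobutyl and 3,3,3-trifluoropropyl, with no step beyond the scatter, even though the hydrogen-bond donor of piperidin-4-yl is lost in the change to compound 4. No measurement at hand accounts for this flat picture.

The compounds shown leave open whether another group on this nitrogen, such as a phenyl ring or a longer chain ending in a carboxylic acid, would give a step beyond the scatter. As far as these compounds go, whether the methyl on the pyrimidine ring of compound 4 contributes anything also remains open.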